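Ring-amine amides in the phenylethynyl thiazole series

The compounds below may be only part of what the source reports. "The series", "measured", "known", "first", "only" and "open" are said of these compounds alone.

Measured compounds in an assay on HEK293 cells for positive allosteric modulation of metabotropic glutamate receptor 5 (Homo sapiens), read by FLIPR, with a stated time of 1 h; a higher number here means that more compound is needed for the effect, a lower number that less compound is needed:
Compound 1, `CN1CCc2nc(C#Cc3ccccc3)sc2C1`, gives 34 nM.
Compound 2, `CCN1CCc2nc(C#Cc3ccccc3)sc2C1`, reaches only the assay limit of > 10000 nM.
Compound 3, `O=C(C1CC1)N1CCc2nc(C#Cc3ccccc3)sc2C1`, likewise returns only the limit, > 10000 nM.

Compound 3 thus stands at the limit, not at a number; (the limit of > 10000 nM in this assay, at which 2 of the 3 values shown sit). Compound 4, `CC1CC(C(=O)N2CCc3nc(C#Cc4ccccc4)sc3C2)C1`, differs from compound 3 by 3-methylcyclobutyl in place of cyclopropyl on a carbonyl carbon. Within the data shown here, the steps that bear on this are an at least 290-fold higher number from compound 1 to compound 3 (2.46 log units; beyond the scatter) and an at least 290-fold higher number from compound 1 to compound 2 (2.46 log units; beyond the scatter), both large, while a step that the two limits leave unreadable from compound 2 to compound 3 cannot be read. Both departures from the methyl amine of compound 1 lose the measured response, and the amide of compound 4 keeps the carbonyl that compound 3 already carries. Compound 4 is therefore expected to remain at or beyond the limit, with a step that the limit leaves unreadable from compound 3 to compound 4 as no readable step. The estimate for compound 4 is 20000 nM, within 5000 nM to 100000 nM.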

Compound 4, half-maximal effective concentration: 81 nM
Compound 4: middle estimate off by 250-fold (2.39 log units), on the high side, outside the stated range (below it).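

In this assay, an amide at this place does not by itself lose the response: keeping the carbonyl and changing only its substituent gives an at least 120-fold lower number from compound 3 to compound 4 (2.09 log units; beyond the scatter), and (3-methylcyclobutyl)carbonyl in place of ethyl gives an at least 120-fold lower number from compound 2 to compound 4 (2.09 log units; beyond the scatter). Compound 4 also comes back close to the methyl amine, with a 2.4-fold higher number from compound 1 to compound 4 (0.38 log units; beyond the scatter), a modest step that is still beyond the scatter. Compound 3 remains a limit rather than a number: the limit of > 10000 nM in this assay, at which 2 of the 4 values shown sit.

Still open, from the compounds shown here alone, is whether the gain needs the larger ring, the methyl on it, or both. Plain cyclobutyl, cyclopentyl or a longer chain on the carbonyl carbon would separate these.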